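The source may hold more compounds than are shown below. What is called first, only, known or untested is meant among the compounds shown, and "the series" means these compounds.

Measured compounds:
compound 1 `CCCCCCCCCCCCCCCCCC/N=c1\nc(N)c2nc[nH]c2c(N)n1` — 2610 nM
compound 2 `Nc1n/c(=N\CCCCc2ccccc2)nc(N)c2c1ncn2Cc1ccccc1` — > 75000 nM

For the measured compounds named here, in a functional assay on PC-3 cells (Homo sapiens) for antiproliferative activity, read by WST assay, with a stated time of 72 h (on this read-out lower numbers stand for stronger inhibition and higher numbers for weaker inhibition), compound 1 gives 2610 nM, the only number among the two values shown. For compound 2 this assay reports only a limit, > 75000 nM, as noted in the limit of > 75000 nM in this assay, at which 1 of the 2 values shown sits. Going by the values given here, compound 2 differs from compound 1 in more than one place, so its limit yields no single step.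

Compound 3 `CCCCCCCCCCCCCCCCCC/N=c1\nc(N)c2ncn(Cc3ccccc3)c2c(N)n1` carries benzyl in place of hydrogen on an aromatic nitrogen. Among the compounds with values here, no measured step of this kind is available. A moderate loss of potency is expected for compound 3, with a 2.3-fold higher number from compound 1 to compound 3 (0.36 log units; beyond the scatter) as the estimated step, because compound 2, which also carries a benzyl on that nitrogen, shows only the limit > 75000 nM. Compound 3 is therefore estimated at 6000 nM, within 1500 nM to 30000 nM.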

Compound 3, half-maximal inhibitory concentration: 5450 nM
For compound 3 the middle estimate is 1.1-fold (0.04 log units) above the measured one; the range from low to high includes it.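

Putting benzyl in place of hydrogen on the aromatic nitrogen gives a 2.1-fold higher number from compound 1 to compound 3 (0.32 log units; beyond the scatter) in this assay. Activity is weakened but not lost, so with the long chain of compound 1 in place, this nitrogen does not need its hydrogen for activity to remain. Compound 2 also carries benzyl there but differs elsewhere too, and its result is only a limit of the assay: the limit of > 75000 nM in this assay, at which 1 of the 3 values shown sits.

Going by these compounds, whether a small methyl or a benzyl bearing a carboxylic acid would fare similarly remains open. So does how the benzyl step changes with a different chain.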